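The compounds below may be only part of what the source reports. "The series", "measured", "known", "first", "only" and "open" are said of these compounds alone.

Compound 1, with structure `CC1=C(C(=O)Nc2ccc(F)cc2)C(c2ccc([N+](=O)[O-])cc2)N=C(SCc2ccccc2Cl)N1`, was tested in a functional assay on the whole organism (artery, strain albino) with Rattus norvegicus as the target, with a stated time of 240 min, at a dose of 10 mg/kg by the oral route (a lower number here means less inhibition, a higher number more inhibition at the dose given (going by the name of the read-out)), and gave 15.9%. Compound 2 has structure `CC1=C(C(=O)Nc2ccc(F)cc2)C(c2ccc([N+](=O)[O-])cc2)N=C(SCc2cccc(Cl)c2)N1` and differs from compound 1 by a change of 3-chlorophenyl in place of 2-chlorophenyl on a saturated chain carbon bound to a sulfur. In this assay compound 2 gave 15.9%, so the step of no change at the digits printed from compound 1 to compound 2 (within the scatter) shows that this change did not move the read-out.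

Compound 3 has structure `COc1ccc(C2N=C(SCc3ccccc3Cl)NC(C)=C2C(=O)Nc2ccc(Br)cc2)cc1`; how its core differs from the core of compound 1 is not broken down here. In this assay compound 3 gave 15.4%, a number within the scatter of both compound 1 and compound 2.

Compound 4, with structure `COc1ccc(C2N=C(SCc3cccc(Cl)c3)NC(C)=C2C(=O)Nc2ccc(Br)cc2)cc1`, has not yet been measured. It differs from compound 3 by 3-chlorophenyl in place of 2-chlorophenyl on a saturated chain carbon bound to a sulfur, the same change that leads from compound 1 to compound 2, at the same place. Because the step of no change at the digits printed from compound 1 to compound 2 (within the scatter) was flat, compound 4 is expected to sit close to compound 3, with an estimated step of no change at the digits printed from compound 3 to compound 4 (within the scatter). Compound 4 is therefore expected to give about 15.4% in this assay, most likely between 5% and 26%.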

Compound 4, a percentage reported as inhibition, in the whole organism at one dose (the size of the read-out at that dose, not a potency): 33.8%
For compound 4 the middle estimate is 18.4 percentage points below the measured one, outside the stated range (above it).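

In this assay, placing 3-chlorophenyl in place of 2-chlorophenyl on a saturated chain carbon bound to a sulfur gives a number 18.4 percentage points higher from compound 3 to compound 4 (beyond the scatter). Within the data shown here, the effect of this change therefore depends on the core that carries it, and a flat step on one core did not carry over to the other: the same change on two cores in this assay, no change at the digits printed (within the scatter) from compound 1 to compound 2 and a number 18.4 percentage points higher (beyond the scatter) from compound 3 to compound 4, 18.4 percentage points apart, beyond the scatter of two such steps This does not show which part of the cores sets the two steps apart, since the core of compound 1 and the core of compound 3 differ in more than one place, and with only two pairs it cannot say how the change would behave on a third core.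

The compounds shown leave open how a benzyl group without chlorine, or a longer chain in place of the chlorobenzyl group, would read on either core in this assay. They also leave open whether the two steps would keep their difference at another dose, since the read-out comes from a single dose and is not a potency.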